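A few compounds are considered here, and "the series" means these few. Any claim that something is new, unique, unknown or untested is made for them only; others in the source may bear on it.

Measured in an assay on isolated protein for inhibition of Retinaldehyde dehydrogenase 3 (Homo sapiens); on this read-out higher numbers stand for weaker inhibition and lower numbers for stronger inhibition:
compound 1, `CC(Sc1nc2c(cnn2C)c(=O)n1-c1ccccc1)c1ccccn1`, gives 89 nM
compound 2, `CC(Sc1nc2nn(C3COC3)cc2c(=O)n1-c1ccccc1)c1ccccc1`, gives 109 nM

Compound 1 has the lower of the two numbers, but compound 2 lies within the usual scatter of it, so the two cannot be separated on this read-out. Compound 3, `CC(Sc1nc2c(cnn2C)c(=O)n1-c1ccccc1)c1cccnc1`, has not yet been measured. It keeps every atom of compound 1 and differs only in how they are joined: pyridin-3-yl in place of pyridin-2-yl on a saturated chain carbon bound to a saturated chain carbon and a sulfur. Going by the values given here, no measured pair isolates this kind of change, so there is no direct guide to its size. Although it differs from compound 1 in more than one place, compound 2 still gives 109 nM, close to the number of compound 1, which hints that changes around this part of the molecule are tolerated. The step of a 1.5-fold higher number from compound 1 to compound 3 (0.16 log units; within the scatter) is therefore expected to stay within the scatter, perhaps a shade toward weaker inhibition. The estimate for compound 3 in this assay is 130 nM, with a range from 50 nM to 400 nM.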

Compound 3, half-maximal inhibitory concentration: 95 nM
Compound 3: the middle estimate sits 1.4-fold (0.14 log units) above what was measured; low and high end bracket the measured number.
By their numbers in this assay, from the lowest: compounds 1, 3 and 2 (each within the scatter of the next).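

In this assay, placing pyridin-3-yl in place of pyridin-2-yl on a saturated chain carbon bound to a saturated chain carbon and a sulfur gives a 1.1-fold higher number from compound 1 to compound 3 (0.03 log units; within the scatter) on this read-out. This is the first pair shown that differs in one place only, so this change can now be judged by itself, and the two pyridine attachments cannot be told apart here. Nothing measured here offers an explanation for this result.

From the compounds shown here alone, whether pyridin-4-yl, or a ring of a different kind such as piperidine, would fit at this place remains open. Also open, going by these compounds, is how a simple amine in place of the pyridine ring, or a longer chain in place of the ethyl link, would read in this assay.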